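A few compounds are considered here, and "the series" means these few. Any claim that something is new, unique, unknown or untested is made for them only; others in the source may bear on it.

In an ADME assay on HEK293 cells (Homo sapiens) for inhibition, read by CellTiter-Glo, with a stated time of 96 h, tested at 100 uM (on this read-out lower numbers stand for less inhibition and higher numbers for more inhibition at the one concentration tested (going by the name of the read-out)), three compounds of one series have been measured. Compound 1 `COC(=O)/C=C\NC(=O)[C@@H](O)C(C)(C)CO` gives -12% in this assay. Compound 2 `CC(C)(CO)[C@H](O)C(=O)N/C=C\C(=O)OCc1ccccc1` gives -7% in this assay. Compound 3 `CC(C)(CO)[C@@H](O)C(=O)N/C=C/C(=O)OCc1ccccc1` gives 5% in this assay, the highest of the three numbers, its step to each of the others lying beyond the scatter.

Two steps link these compounds. The change hydrogen in place of phenyl on a saturated chain carbon bound to an oxygen next to a carbonyl group produces a number 5 percentage points lower from compound 2 to compound 1 (within the scatter), a step within the scatter, so the two values show no real difference. The change the two compounds have the same atoms and bonds and differ only in configuration as drawn: 2 of 2 stereo elements differ; a stereocentre at a saturated chain carbon is drawn S in compound 2 and R in compound 3; a double bond is drawn Z in compound 2 and E in compound 3 produces a number 12 percentage points higher from compound 2 to compound 3 (beyond the scatter), a modest step beyond the scatter; the two compounds have the same atoms and bonds and differ only in configuration as drawn (the fact that compounds 2 and 3 differ only in the configuration as drawn).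

Compound 4 `COC(=O)/C=C/NC(=O)[C@H](O)C(C)(C)CO` has not yet been measured in this assay. It is related to compound 3 by hydrogen in place of phenyl on a saturated chain carbon bound to an oxygen next to a carbonyl group, which is the same change as that from compound 2 to compound 1, made on a core that differs from the core of compound 2 only in configuration (the two compounds have the same atoms and bonds and differ only in configuration as drawn: 2 of 2 stereo elements differ; a stereocentre at a saturated chain carbon is drawn S in compound 2 and R in compound 3; a double bond is drawn Z in compound 2 and E in compound 3); the place of the change is the same in both pairs. Since that change gave only a number 5 percentage points lower from compound 2 to compound 1 (within the scatter), a small step is expected again, and the step from compound 3 to compound 4 is estimated as a number 5 percentage points lower from compound 3 to compound 4 (within the scatter). On this basis compound 4 is expected to give about 0% in this assay, with a likely range from -15% to 15%.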

Compound 4, a percentage reported as inhibition, at one concentration (the size of the read-out at that concentration, not a potency): 0%
Beside the measured number, compound 4's estimate shows no gap at the digits printed; the range from low to high includes it.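

In this assay, hydrogen in place of phenyl on a saturated chain carbon bound to an oxygen next to a carbonyl group gives a number 5 percentage points lower from compound 3 to compound 4 (within the scatter), and the step carries over from one core to the other without a difference between them: the same change on two cores in this assay, a number 5 percentage points lower (within the scatter) from compound 2 to compound 1 and a number 5 percentage points lower (within the scatter) from compound 3 to compound 4, 0 percentage points apart, within the scatter of two such steps Since neither step lies beyond the scatter, what carries over is the absence of a readable difference rather than an effect of known size, and it is shown only on two cores that differ from each other in configuration as drawn, not on a core with different atoms or bonds. The configuration difference on the shared core now also appears as a number 12 percentage points higher from compound 1 to compound 4 (beyond the scatter), a modest step in which the stereocentre and the double bond differ together, leaving the share of each unresolved: the fact that compounds 1 and 4 differ only in the configuration as drawn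

The compounds shown leave open what the stereocentre or the double bond does alone, since in both configuration pairs the two differ at once. They also leave open whether a carboxylic acid or a longer chain in the place where benzyl and methyl stand would give a step beyond the scatter.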